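This account rests on a few compounds, and the source may have more. Where it says the series, first, only, none or still open, it means among the compounds named here.

Working notes on the series. In a functional assay on HepG2 cells (Homo sapiens) for inhibition, read by MTT assay, with a stated time of 48 h (a lower number here means a stronger inhibitor, a higher number a weaker inhibitor), compound 1 `COc1cc(-c2nnc(SCc3ccccc3)n2-c2ccc(N(C)C)cc2)cc(OC)c1OC` gives > 60000 nM, which is a limit and not a number. Compound 2 `COc1ccc(C(=O)CSc2nnc(-c3cc(OC)c(OC)c(OC)c3)n2-c2ccc(N(C)C)cc2)cc1O` gives > 100000 nM, also a limit, so it has no exact place in the series. Among the compounds with values here, the only measured step, a step that the two limits leave unreadable from compound 1 to compound 2, has no readable size and offers nothing to carry forward.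

The next compound is compound 3 `COc1cc(-c2nnc(SCC(=O)c3ccc4ccccc4c3)n2-c2ccc(N(C)C)cc2)cc(OC)c1OC`, which keeps the core of compound 2. The difference is naphthalen-2-yl in place of 3-hydroxy-4-methoxyphenyl on a carbonyl carbon, with naphthalen-2-yl in place of 3-hydroxy-4-methoxyphenyl on a carbonyl carbon. Within the data shown here, no measured step covers this exchange, so the expectation is weakly founded, and a further limit would be no surprise.

A real number for compound 3 could be read only on the stronger side, because compound 2 gives > 100000 nM, which is a limit. The expected at least 3.3-fold lower number from compound 2 to compound 3 (0.52 log units; beyond the scatter) therefore points toward stronger inhibition in this assay, with its size uncertain. For compound 3 the estimated value is 30000 nM, with an expected range of 3000 nM to 100000 nM.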

Compound 3, half-maximal inhibitory concentration: > 60000 nM
Compound 3 was reported as a limit (the forecaster's own chance of this, stated with the estimate: 35%); middle value at least 2.0-fold (0.30 log units) from the limit.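

No step can be read among compound 1, compound 2 and compound 3, because every value in this assay is a limit and not a number: the limit of > 60000 nM in this assay, at which 2 of the 3 values shown sit.

The compounds shown leave open whether any of these exchanges on the saturated chain carbon bound to a sulfur changes inhibition in this assay, and by how much.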